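This account rests on a few compounds, and the source may have more. Where it says the series, first, only, none or still open, it means among the compounds named here.

Compound 1 `CN1Cc2ccc(OCc3ccc([N+](=O)[O-])cc3)cc2[C@@H](O)C1` was tested in an ADME assay on Vero cells (Chlorocebus sabaeus) for cytotoxicity, read by sulforhodamine B assay, with a stated time of 72 h; a higher number here means a weaker inhibitor, a lower number a stronger inhibitor. In that assay compound 1 gives only a limit, > 50000 nM. Two companions from the same series share its core. Compound 2 `Cc1cccc(COc2ccc3c(c2)[C@@H](O)CN(C)C3)c1` carries a 3-methylbenzyl ether, and in this assay compound 2 also gives a limit, > 50000 nM. Compound 3 `CN1Cc2ccc(OCCCn3cnc([N+](=O)[O-])c3)cc2[C@@H](O)C1` carries a nitroimidazolylpropyl ether, and in this assay compound 3 gives a limit as well, > 50000 nM. So compound 1 stands where every measured member stands: the data show (the limit of > 50000 nM in this assay, at which 3 of the 3 values shown sit), and no compound among the three has a number that would set it apart from the others.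

The step under consideration leads to compound 4 `COc1cccc(-c2ccc(COc3ccc4c(c3)[C@@H](O)CN(C)C4)cc2)c1`. Relative to compound 1 the change is 3-methoxyphenyl in place of nitro on an aromatic carbon. With no measured step between any pair of these compounds, there is nothing in the set from which a direction or size could be read. The expectation for the step from compound 1 to compound 4 is therefore a number no higher from compound 1 to compound 4 (the limit leaves the size open), that is, nothing beyond the usual scatter. Compound 4 is expected to give about 50000 nM in this assay, within a range from 15000 nM to 150000 nM, most likely again reported only as a limit.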

Compound 4, half-maximal inhibitory concentration: 10800 nM
Compound 4: middle estimate off by 4.6-fold (0.67 log units), on the high side; the whole stated range lies above it.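

Within the data shown here, on the aromatic carbon para to a large group, 3-methoxyphenyl in place of nitro gives an at least 4.6-fold lower number from compound 1 to compound 4 (0.66 log units; beyond the scatter) in this assay, so this position can move the result by more than the usual scatter, which the earlier compounds could not show. Compound 1 gives > 50000 nM, which is a limit, so the step has a lower bound but no fixed size. Among the compounds shown, compound 4 alone has a number in this assay, and the other three remain at one shared limit: the limit of > 50000 nM in this assay, at which 3 of the 4 values shown sit.

The compounds shown leave open whether the step belongs to the added aromatic ring or to its methoxy group, as nitro left and the whole 3-methoxyphenyl entered in a single change. Going by these compounds, it also remains open how a plain phenyl, an amine or a carboxylic acid on the same aromatic carbon would read in this assay, and so whether any large group there lowers the number or only this one does.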